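This account rests on a few compounds, and the source may have more. Where it says the series, first, only, none or still open, it means among the compounds named here.

Of the compounds shown here, three have been measured in a physicochemical assay for lipophilicity, at pH 7.4; a higher number here means a more lipophilic compound, a lower number a more polar compound. Compound 1, with the structure `CNC(=O)c1cccn(Cc2ccccc2)c1=O`, gives 3 in this assay. Compound 2, `CNC(=O)c1cc(C(=O)NC2CC2)cn(Cc2cccc3[nH]ccc23)c1=O`, gives 2.9 in this assay, a number that sits within the usual scatter of compound 1. Compound 3, `CNC(=O)c1cc(C(=O)NC2CC2)cn([C@H](C)c2ccccc2)c1=O`, gives 3.4 in this assay, a number beyond the scatter above compound 1. Among the three, compound 1 thus stands second highest.

Compound 4, `CNC(=O)c1cc(C(=O)NC)c(=O)n(Cc2ccccc2)c1`, has not yet been measured. It differs from compound 1 in one place: methylcarbamoyl in place of hydrogen on an aromatic carbon.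

Going by the values given here, no pair of measured compounds differing in a single place is available, so the size of this step is not known from the data. The expectation is a downward step in this assay that exceeds the scatter, with the step from a number 0.60 log units lower from compound 1 to compound 4 (beyond the scatter) as the estimate. For compound 4 the expected value in this assay is 2.4, with a likely range from 1.9 to 2.9.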

Compound 4, distribution coefficient: 2.4
Compound 4: the middle estimate sits on the measured number at the digits printed; low and high end bracket the measured number.
By their numbers in this assay, from the lowest: compound 4; then compounds 2 and 1 (each within the scatter of the next); then compound 3.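

Going by these compounds alone, replacing hydrogen with methylcarbamoyl on this aromatic carbon, two atoms from the ring nitrogen, gives the first step in this assay that can be tied to a single change: a number 0.60 log units lower from compound 1 to compound 4 (beyond the scatter). The earlier compounds shown here differ from one another in more than one place, so they could not show what this position alone contributes. Nothing measured here accounts for the size or direction of this step.

The compounds shown leave open how other groups on the same carbon, such as a nitrile, a carboxylic acid or an amide with a longer chain, would compare with methylcarbamoyl in this assay. They also leave open whether the same change would give a step of similar size with something other than the benzyl group on the ring nitrogen.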